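The source may report more compounds than this note shows. Statements on the series, on what has been measured and on what is new or still open speak of the compounds shown alone.

Measured compounds:
compound 1, `N#Cc1cnc(NCc2cnccc2C(F)(F)F)cc1N[C@H]1C[C@@H](O)C1`, 500 nM
compound 2, `N#Cc1cnc(NCc2cnccc2C(F)(F)F)cc1NCC1CCOCC1`, 400 nM
compound 3, `N#Cc1cnc(NCc2cnccc2C(F)(F)F)cc1N[C@H]1CC[C@@H](C(N)=O)CC1`, 7 nM

In an assay on isolated protein for inhibition of protein kinase C theta type (Homo sapiens), read by TR-FRET, with a stated time of 2 h (a higher number here means a weaker inhibitor, a lower number a stronger inhibitor), compound 3 gives the lowest number of the three, with compound 2 the nearest and compound 1 the furthest. Both steps that bring in the 4-carbamoylcyclohexyl group were large: a 71-fold lower number from compound 1 to compound 3 (1.85 log units; beyond the scatter) and a 57-fold lower number from compound 2 to compound 3 (1.76 log units; beyond the scatter), whereas a 1.3-fold lower number from compound 1 to compound 2 (0.10 log units; within the scatter). Compound 4, `CC1(C)[C@@H](Nc2cc(NCc3cnccc3C(F)(F)F)ncc2C#N)C[C@@H]1C(N)=O`, is not yet measured in this assay. It has the same atoms as compound 3, joined differently: 3-carbamoyl-2,2-dimethylcyclobutyl in place of 4-carbamoylcyclohexyl on a nitrogen on an aromatic ring. Within the data shown here, because a 71-fold lower number from compound 1 to compound 3 (1.85 log units; beyond the scatter) and a 57-fold lower number from compound 2 to compound 3 (1.76 log units; beyond the scatter) accompanied the entry of the carbamoyl group, which compound 4 keeps, a large loss is not expected, though no measured step shows how a four-membered ring compares with a six-membered one. Compound 4 is expected to give 30 nM (range 7 nM to 150 nM), an expected step of a 4.3-fold higher number from compound 3 to compound 4 (0.63 log units; beyond the scatter).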

Compound 4, half-maximal inhibitory concentration: 1100 nM
Compound 4: middle estimate off by 37-fold (1.56 log units), on the low side, and the stated range ends below it.
By their numbers in this assay, from the lowest: compound 3; then compounds 2 and 1 (each within the scatter of the next); then compound 4.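

In this assay the carbamoyl group alone does not carry the gain at this nitrogen: a 160-fold higher number from compound 3 to compound 4 (2.20 log units; beyond the scatter) comes with nothing more than the same atoms joined as 3-carbamoyl-2,2-dimethylcyclobutyl. Against the groups without a carbamoyl, a 2.8-fold higher number from compound 2 to compound 4 (0.44 log units; beyond the scatter) and a 2.2-fold higher number from compound 1 to compound 4 (0.34 log units; beyond the scatter) show that compound 4 does not even match them. Nothing available explains this loss. Open, going by these compounds, is whether it follows the four-membered ring or the 2,2-dimethyl pair. Also open, on these data alone, is whether a carboxylic acid or an amine could replace the carbamoyl on the cyclohexyl ring of compound 3.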